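Thiophen-2-yl for Phenyl on the Imine Carbon

This account rests on a few compounds, and the source may have more. Where it says the series, first, only, none or still open, it means among the compounds named here.

Compound 1 `NS(=O)(=O)c1ccc(Nc2ncc(/N=C/c3cccs3)c(NC3CCCC3)n2)cc1`: 9950 nM
Compound 2 `CCOC(=O)/C=N/c1cnc(Nc2ccc(S(N)(=O)=O)cc2)nc1NC(C)C`: a limit, > 100000 nM
Compound 3 `CC(C)Nc1nc(Nc2ccc(S(N)(=O)=O)cc2)ncc1/N=C/c1ccccc1`: 98200 nM

In a functional assay on HT-29 cells (Homo sapiens) for antiproliferative activity, read by MTT assay (on this read-out lower numbers stand for stronger inhibition and higher numbers for weaker inhibition), compound 3 gives 98200 nM, the higher of the two numbers shown. Its nearest neighbour is compound 1, which in this assay gives 9950 nM, a lower number that lies beyond the scatter. Compound 2 reports only a limit in this assay, > 100000 nM, not a number.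

Compound 4 `CC(C)Nc1nc(Nc2ccc(S(N)(=O)=O)cc2)ncc1/N=C/c1cccs1` arises from compound 3 by one exchange: thiophen-2-yl in place of phenyl on a carbon with a double bond to nitrogen. Among the compounds with values here, the single measured step that touches this carbon is an at least 1.0-fold lower number from compound 2 to compound 3 (0.00 log units; that floor lies within the scatter); since compound 2 sits at the limit of > 100000 nM in this assay, at which 1 of the 3 values shown sits, the size of that step is unknown, and it concerns a different exchange. Compounds 1 and 4 share the thiophen-2-yl group, but compound 1 also carries a different amine on the shared core, so the gap between compound 1 and compound 3 cannot be assigned to the thiophen-2-yl alone.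

The expectation for compound 4 therefore rests loosely on compound 1 giving 9950 nM: a lower number than compound 3 is expected, by about a 2.5-fold lower number from compound 3 to compound 4 (0.39 log units; beyond the scatter). Compound 4 is estimated at 40000 nM, with a range of 8000 nM to 150000 nM.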

Compound 4, half-maximal inhibitory concentration: > 100000 nM
Compound 4: a limit, no number; the forecaster's own chance of this, stated with the estimate: 25%; middle value at least 2.5-fold (0.39 log units) away from the limit.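

In this assay compound 4 reports only a limit, not a number, so the step between it and compound 2 cannot be read: the limit of > 100000 nM in this assay, at which 2 of the 4 values shown sit.

With isopropyl on the nitrogen, the exchange of phenyl for thiophen-2-yl on the carbon with a double bond to nitrogen comes out as an at least 1.0-fold higher number from compound 3 to compound 4 (0.00 log units; that floor lies within the scatter), so at this position the thiophen-2-yl brings no readable gain. The pair that does read holds thiophen-2-yl fixed and changes the amine substituent: isopropyl in place of cyclopentyl on a nitrogen on an aromatic ring gives an at least 10-fold higher number from compound 1 to compound 4 (1.00 log units; beyond the scatter), so the measurable number of compound 1 goes with the cyclopentyl and not with the thiophen-2-yl alone.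

Compound 1 gives 9950 nM, and the compounds shown leave open whether a cyclohexyl or a longer alkyl chain on that nitrogen would give a lower number. They also leave open whether phenyl paired with cyclopentyl would give a number at all, and how a furan-2-yl on the carbon with a double bond to nitrogen would compare with thiophen-2-yl.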